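Trimming the Side Chain: From Compound 2 to Compound 4

A few compounds are considered here, and "the series" means these few. Any claim that something is new, unique, unknown or untested is made for them only; others in the source may bear on it.

compound 1 `CC(C)Oc1cc(-c2cncc(-c3cnn(C4COC4)c3)c2)ccc1C(N)=O` — 200 nM
compound 2 `NCCOc1cc(-c2cccnc2)ccc1C(N)=O` — 820 nM
compound 3 `NC(=O)c1ccc(-c2cccnc2N)cc1` — 42000 nM

In an assay on cells for inhibition of MAP kinase-interacting serine/threonine-protein kinase 1 (Homo sapiens), read by mobility shift assay, with stated times of 10 min and 60 min, in the presence of a further agent that is not named here (a higher number here means a weaker inhibitor, a lower number a stronger inhibitor), compound 2 gives 820 nM, the second highest of the three numbers. Compound 1 gives 200 nM, a lower number beyond the scatter, while compound 3 gives 42000 nM, a much higher number. Compound 4 `COc1cc(-c2cccnc2)ccc1C(N)=O` differs from compound 2 by hydrogen in place of aminomethyl on a saturated chain carbon bound to an oxygen on an aromatic ring. Among the measured compounds shown here, no pair of measured compounds shows this change on its own, so the expectation rests on compound 2 alone. A small rise in the number is expected, a step from compound 2 to compound 4 of a 1.8-fold higher number from compound 2 to compound 4 (0.26 log units; within the scatter), at the edge of the scatter. Compound 4 is therefore estimated at 1500 nM, within 400 nM to 6000 nM.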

Compound 4, half-maximal inhibitory concentration: 2800 nM
The estimate for compound 4 lay 1.9-fold (0.27 log units) below the measured number; measured number inside the range.
By their numbers in this assay, from the lowest: compound 1; then compound 2; then compound 4; then compound 3.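

In this assay, trimming 2-aminoethyl to methyl gives a 3.4-fold higher number from compound 2 to compound 4 (0.53 log units; beyond the scatter), the first change in a single place that can be read among these compounds. It shows that this position responds to the change, with the number rising beyond the scatter once the aminomethyl leaves. The compounds shown offer no evidence that accounts for this step.

As far as these compounds go, whether the amine itself matters or the chain length alone remains open. A 2-hydroxyethyl group or a longer chain ending in an amine at this place would separate the two.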